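Notes on the step from compound 3 to compound 4

The source may report more compounds than this note shows. Statements on the series, on what has been measured and on what is new or still open speak of the compounds shown alone.

Within the data shown here, in a physicochemical assay for solubility (on this read-out higher numbers stand for higher solubility and lower numbers for lower solubility), compound 3 (`CCOc1ccc2c(c1)C(c1cnn(C)c1)=CN(C)C(=O)[C@@H]2C`) gives 143 ug/mL as the only true number in the set. Compound 1 (`C[C@H]1C(=O)N(C)C=Cc2cc(C(O)CO)ccc21`) reads >= 101 ug/mL and this is a limit of the assay. Compound 2 (`CCS(=O)(=O)c1ccc2c(c1)C(c1cnn(C)c1)=CN(C)C(=O)[C@@H]2C`) reads >= 222 ug/mL and this too is a limit. Compound 4 (`CCOc1ccc2c(c1)C(c1c[nH]c(C)n1)=CN(C)C(=O)[C@@H]2C`) carries 2-methyl-1H-imidazol-4-yl in place of 1-methyl-1H-pyrazol-4-yl on a double-bonded ring carbon. Among the measured compounds shown here, the one measured step is an at least 1.5-fold lower number from compound 2 to compound 3 (0.19 log units; that floor lies within the scatter) and it concerns ethoxy in place of ethylsulfonyl on an aromatic carbon, so it gives no size for this change. No step beyond the scatter is therefore expected, though the uncertainty is wide. The expected step is a 1.0-fold higher number from compound 3 to compound 4 (0.02 log units; within the scatter) in this estimate. The estimate for compound 4 is 150 ug/mL with an expected range of 60 ug/mL to 350 ug/mL in this assay here.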

Compound 4, solubility: >= 135 ug/mL
Compound 4 ended at the assay's limit (the forecaster's own chance of this, stated with the estimate: 30%); the middle value is on the limit's open side.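

In this assay no step can be read from compound 3 to compound 4, whose value is a limit: the limit of >= 135 ug/mL in this assay, at which 1 of the 4 values shown sits.

In this assay the compounds shown leave open how 2-methyl-1H-imidazol-4-yl and 1-methyl-1H-pyrazol-4-yl compare on the shared core.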